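The compounds below may be only part of what the source reports. "The series", "measured", "known", "first", "only" and "open" are said of these compounds alone.

Working notes on the series in a functional assay on HCT-116 cells (Homo sapiens) for antiproliferative activity, read by sulforhodamine B assay, with a stated time of 72 h; on this read-out lower numbers stand for stronger inhibition and higher numbers for weaker inhibition.

Of the compounds shown here, three carry numbers so far. Compound 1 `Cn1ncc(Cl)c1-c1cc(C(=O)N[C@@H]2CN[C@H](CCN3CCC(O)CC3)C[C@H]2c2ccc(Cl)c(Cl)c2)oc1Cl` gives 13700 nM in this assay. Compound 2 `Cn1ncc(Cl)c1-c1cc(C(=O)N[C@@H]2CNCC[C@H]2c2ccc(C(F)(F)F)cc2)oc1Cl` gives 280 nM in this assay; it lacks the (4-hydroxypiperidin-1-yl)methyl group of compound 1 and differs from it elsewhere as well. Compound 3 `O=C(N[C@@H]1CNCC[C@H]1c1ccc(Cl)cc1)c1ccc(-c2ncnc3c2CCC3O)s1`, built on another core, gives 23000 nM in this assay. Among these three numbers compound 1 stands second highest. Its nearest neighbour is compound 3, whose number lies within the usual scatter of that of compound 1, so nothing separates the two. Compound 2 sits far lower, well beyond the scatter, so the gap between compound 1 and compound 2 is a real one.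

Compound 4 `Cn1ncc(Cl)c1-c1cc(C(=O)N[C@@H]2CN[C@H](CC(=O)NC3CC3)C[C@H]2c2ccc(Cl)c(Cl)c2)oc1Cl` has not yet been measured. It differs from compound 1 in one place: cyclopropylcarbamoyl in place of (4-hydroxypiperidin-1-yl)methyl on a saturated chain carbon bound to a saturated ring carbon. Among the measured compounds shown here, no pair of measured compounds spans exactly this change, so its size must be guessed. Because compound 2 gives 280 nM while lacking the (4-hydroxypiperidin-1-yl)methyl group, the expectation for compound 4 is a moderate step downward, beyond the scatter, as in a 4.6-fold lower number from compound 1 to compound 4 (0.66 log units; beyond the scatter). Compound 4 is therefore estimated at 3000 nM, with a range from 600 nM to 15000 nM.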

Compound 4, half-maximal inhibitory concentration: 740 nM
Estimate against measurement, compound 4: 4.1-fold (0.61 log units) above, and the stated range covers the measured number.
By their numbers in this assay, from the lowest: compound 2; then compound 4; then compounds 1 and 3 (each within the scatter of the next).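

In this assay, among the compounds shown here, the first change that can be read in one place shows that this saturated chain carbon bound to a saturated ring carbon does not tolerate all groups alike: cyclopropylcarbamoyl in place of (4-hydroxypiperidin-1-yl)methyl gives a 19-fold lower number from compound 1 to compound 4 (1.27 log units; beyond the scatter). The step is large, and the rest of compound 1 stays as it is, so it belongs to this one change, in which a six-membered non-aromatic ring with 1 hetero atom leaves and a three-membered non-aromatic ring of carbon only enters, along with a double bond outside aromatic rings. No independent measurement bears on why the number moves.

One pair cannot tell whether the step follows from the arrival of the cyclopropylcarbamoyl group, from the departure of the (4-hydroxypiperidin-1-yl)methyl group, or from both. A chain at this place ending in a carboxylic acid, or a primary amide in place of cyclopropylcarbamoyl, would begin to separate these readings.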